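A few compounds are considered here, and "the series" means these few. Any claim that something is new, unique, unknown or untested is made for them only; others in the source may bear on it.

Measured compounds:
- compound 1, `CCCCCCCCNC(=O)[C@@H](NC(=O)c1ccco1)[C@@H](C)O`, gives 200000 nM in a functional assay on SW-620 cells (Homo sapiens) for cytotoxicity, read by MTT assay, with a stated time of 48 h; a lower number here means a stronger inhibitor, a higher number a weaker inhibitor
- compound 2, `CCCCCCCCNC(=O)[C@@H](NC(=O)c1cccs1)[C@@H](C)O`, gives 136000 nM in this assay
- compound 3, `CCCCCCCCNC(=O)[C@@H](NC(=O)/C=C/c1ccccc1)[C@@H](C)O`, gives 61400 nM in this assay

Compound 1 has the highest number of the three, so it is the weakest inhibitor among them. The three measured compounds differ only in the group attached to one carbonyl carbon, and the steps between them are small to modest: a 1.5-fold lower number from compound 1 to compound 2 (0.17 log units; within the scatter), a 3.3-fold lower number from compound 1 to compound 3 (0.51 log units; beyond the scatter) and a 2.2-fold lower number from compound 2 to compound 3 (0.35 log units; beyond the scatter).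

Compound 4, `CCCCCCCCCCCCCCNC(=O)[C@@H](NC(=O)c1ccco1)[C@@H](C)O`, changes a different part of the molecule. Relative to compound 1 the difference is hexyl in place of hydrogen on a saturated chain carbon, eight bonds along the chain from an amide-type nitrogen. Within the data shown here, none of the measured steps touches the chain on the other side of the core; they all concern the group on the carbonyl carbon. Among the measured compounds shown here, there is therefore no measured step that bears directly on this change, and the measured data give no guide to its direction.

With nothing to anchor a direction, the expected outcome in this assay for compound 4 is a step of a 1.3-fold lower number from compound 1 to compound 4 (0.12 log units; within the scatter), which is to say no clear change beyond the scatter. The estimate for compound 4 is 150000 nM, with a range from 40000 nM to 400000 nM.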

Compound 4, half-maximal inhibitory concentration: 200000 nM
For compound 4 the middle estimate is 1.3-fold (0.12 log units) below the measured one, and the stated range covers the measured number.
By their numbers in this assay, from the lowest: compound 3; then compounds 2, 1 and 4 (each within the scatter of the next).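

In this assay, among these compounds, the chain on the amide-type nitrogen can now be read for the first time, and hexyl in place of hydrogen on a saturated chain carbon, eight bonds along the chain from an amide-type nitrogen, gives no change at the digits printed from compound 1 to compound 4 (within the scatter). Among the compounds shown here, all the earlier steps concerned the group on the carbonyl carbon, so they said nothing about this side of the molecule, whereas this pair shows that, with furan-2-yl held in place, a much longer saturated chain leaves the number where it was. No measured evidence here speaks to why this added length makes no difference.

For the compounds shown here, one pair gives only two chain lengths, so it remains open whether a shorter chain such as butyl, or a chain of similar length ending in an amine or a carboxylic acid, would also leave the number unchanged. As far as these compounds go, it is also open whether the same lengthening would give the same result with thiophen-2-yl or 2-phenylethenyl on the carbonyl carbon in place of furan-2-yl.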